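The compounds below may be only part of what the source reports. "The series", "measured", "known", "first", "only" and "open" are said of these compounds alone.

Measured compounds:

Compound 1, `COc1cc(-c2cc(/C=C/C(=O)c3ccc(N)cc3)[nH]n2)cc(OC)c1OC`, in a functional assay on 786-0 cells (Homo sapiens) for inhibition, read by sulforhodamine B assay, with a stated time of 48 h (on this read-out lower numbers stand for stronger inhibition of growth and higher numbers for weaker inhibition of growth), gives 2040 nM.
Compound 2, `COc1ccc(-c2cc(/C=C/C(=O)c3ccc(N)cc3)[nH]n2)cc1OC`, gives in this assay 1880 nM.
Compound 3, `COc1cc(C(=O)/C=C/c2cc(-c3cc(OC)c(OC)c(OC)c3)n[nH]2)cc(OC)c1OC`, gives in this assay 1560 nM.

The three values sit close together. Among the compounds with values here, the only change between measured compounds that can be counted is the one from compound 1 to compound 2: hydrogen in place of methoxy on an aromatic carbon. This step gave a 1.1-fold lower number from compound 1 to compound 2 (0.04 log units; within the scatter). Within the data shown here, compound 3 carries the same two aromatic rings as compound 1 but arranged on a different core; the difference between the two cores is not broken down here, and what can be said is only that the values of compound 1 and compound 3 lie within the scatter of one another.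

Compound 4, `COc1ccc(-c2cc(/C=C/C(=O)c3cc(OC)c(OC)c(OC)c3)[nH]n2)cc1OC`, has not yet been measured in this assay. It arises from compound 3 by the following change: hydrogen in place of methoxy on an aromatic carbon. Among the measured compounds shown here, the surroundings of the changed position are the same in both cases, so this is the same change as the one from compound 1 to compound 2.

For compound 4 the expected step is a 1.1-fold lower number from compound 3 to compound 4 (0.05 log units; within the scatter), and this rests on the earlier step in this assay, because a 1.1-fold lower number from compound 1 to compound 2 (0.04 log units; within the scatter) showed no movement beyond the scatter. Compound 4 is therefore estimated at 1400 nM in this assay, with a likely range from 700 nM to 2800 nM.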

Compound 4, concentration for 50% growth inhibition: 1500 nM
The estimate for compound 4 lay 1.1-fold (0.03 log units) below the measured number; measured number inside the range.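

In this assay, hydrogen in place of methoxy on an aromatic carbon gave a 1.0-fold lower number from compound 3 to compound 4 (0.02 log units; within the scatter), so this change again produced no movement beyond the scatter, as it had on the core of compound 1. Set side by side, the two steps do not differ: the same change on two cores in this assay, a 1.1-fold lower number (0.04 log units; within the scatter) from compound 1 to compound 2 and a 1.0-fold lower number (0.02 log units; within the scatter) from compound 3 to compound 4, 1.0-fold (0.02 log units) apart, within the scatter of two such steps This shows that in this assay the change carried over from one core to the other as a step within the scatter; it does not show that the methoxy group at this place has no role in general, and two cores give no rule for the rest of the series, while steps this small could hide a modest difference between the cores.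

The compounds shown leave open whether any replacement at this place would move the number beyond the scatter, for only methoxy and hydrogen are seen there, and a hydroxyl, a chlorine atom or a longer chain such as butoxy could behave differently. As far as these compounds go, it also remains open whether the same step would hold on a core bearing other groups on the second aromatic ring, such as a carboxylic acid or a nitrile.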